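The source may hold more compounds than are shown below. What is called first, only, known or untested is meant among the compounds shown, and "the series" means these compounds.

Compound 1 `NC(=O)CCNC(=O)c1cccc(S)c1`: in an ADME assay on CEM-SS cells (Homo sapiens) for cytotoxicity, read by XTT assay, with a stated time of 6 days (a lower number here means that less compound is tolerated, a higher number that more compound is tolerated), compound 1 gives > 100 uM, which is a limit of the assay and not a number.
Compound 2 `CCCC(=O)OCSc1ccccc1C(=O)NCCCCCCC(N)=O`: in this assay compound 2 gives 10.4 uM.
Compound 3 `CCCC(=O)OCSc1ccccc1C(=O)Nc1ccc(C(N)=O)cc1`: in this assay compound 3 gives 39 uM.

Three compounds share a core that carries a thioether and an amide, and all were run in this assay. Of the two that returned a number, compound 2 stands lowest, so it is the least tolerated of the pair. Compound 3 gives a higher number, and that gap is beyond the usual scatter of repeated measurements. Compound 1 stands apart at the limit of > 100 uM in this assay, at which 1 of the 3 values shown sits.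

The next compound, compound 4 `CCCC(=O)OCSc1ccccc1C(=O)NC`, has not yet been measured in this assay. Against compound 2 it differs in one place: hydrogen in place of 5-carbamoylpentyl on a saturated chain carbon bound to an amide-type nitrogen.

For the measured compounds named here, no measured pair in this set differs in exactly one place, so the size of this step is open. Still, the step of a 3.8-fold higher number from compound 2 to compound 4 (0.59 log units; beyond the scatter) is expected to go upward, toward more compound being tolerated, and to reach beyond the scatter. This expectation leans on compound 1, the simplest compound shown, which sits at the limit of > 100 uM in this assay, at which 1 of the 3 values shown sits. Compound 4 is therefore estimated at about 40 uM, within a range from 12 uM to 100 uM.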

Compound 4, half-maximal toxic concentration: 5.7 uM
The estimate for compound 4 lay 7.0-fold (0.85 log units) above the measured number; the whole stated range lies above it.
By their numbers in this assay, from the lowest: compounds 4 and 2 (each within the scatter of the next); then compound 3. At a limit, above all of these: compound 1.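

In this assay the exchange of 5-carbamoylpentyl for hydrogen, on a saturated chain carbon bound to an amide-type nitrogen, gives a 1.8-fold lower number from compound 2 to compound 4 (0.26 log units; within the scatter). For the compounds shown here, a group of 8 heavy atoms, including a terminal amide, can therefore leave this place without a change that can be told from repeat-measurement noise, at least for this pair, and this is the first direct reading of a single change in the set. The pair offers no reason for this flat result, and nothing else measured here explains it.

The compounds shown leave open whether the same holds for a short group such as ethyl, or for a chain of similar length that ends in a carboxylic acid or an amine instead of the amide. They also leave open which single change separates compound 1 from the others, as compound 1 differs from each of them in more than one place and no compound shown links them one change at a time.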